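Replacing bromo with chloro: an expected step

This account rests on a few compounds, and the source may have more. Where it says the series, first, only, none or still open, it means among the compounds named here.

Measured in a functional assay on DU-145 cells (Homo sapiens) for inhibition (on this read-out higher numbers stand for weaker inhibition of growth and lower numbers for stronger inhibition of growth), so far:
- Compound 1 (`O=S(=O)(/C=C/c1ccc(F)cc1)Cc1ccc(Nc2ncnc3ccccc23)cc1`) gives 300 nM here
- Compound 2 (`O=S(=O)(/C=C/c1ccc(Br)cc1)Cc1ccc(Nc2ncnc3ccccc23)cc1`) gives 55000 nM here

Compound 2 has the higher of the two numbers and so the weaker inhibition of growth. Compound 3 (`O=S(=O)(/C=C/c1ccc(Cl)cc1)Cc1ccc(Nc2ncnc3ccccc23)cc1`) differs from it by one change (chloro in place of bromo on an aromatic carbon): chloro in place of bromo on an aromatic carbon. For the measured compounds named here, only one measured step bears on this, the large one (a 180-fold higher number from compound 1 to compound 2 (2.26 log units; beyond the scatter)) for bromo in place of fluoro. Chloro falls between those two halogens, so a sizeable move to a lower number in this assay is expected, though the data hold no chloro example to confirm it. The expected step (an 18-fold lower number from compound 2 to compound 3 (1.26 log units; beyond the scatter)) recovers much of that loss. Compound 3 is estimated at 3000 nM (range 350 nM to 30000 nM).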

Compound 3, concentration for 50% growth inhibition: > 100000 nM
Compound 3 ended at the assay's limit; the forecaster's own chance of this, stated with the estimate: 5%; middle value at least 33-fold (1.52 log units) away from the limit.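

Replacing bromo with chloro at this position brought no recovery in this assay: the step reads an at least 1.8-fold higher number from compound 2 to compound 3 (0.25 log units; that floor lies within the scatter), so the two compounds cannot be placed in order. Fluoro stands apart from chloro here, with an at least 330-fold higher number from compound 1 to compound 3 (2.52 log units; beyond the scatter). The reading for compound 3 is a limit of the assay and not a number: the limit of > 100000 nM in this assay, at which 1 of the 3 values shown sits.

The compounds shown leave open how far chloro lies beyond bromo. They also leave open how a methyl, a methoxy or a nitrile in this place would read, and whether any of these would come close to fluoro.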